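Trading trifluoromethoxy for trifluoromethyl on compound 2

The source may report more compounds than this note shows. Statements on the series, on what has been measured and on what is new or still open speak of the compounds shown alone.

Compound 1 `O=S1(=O)C=Cc2cccc(Nc3cccc(C(F)(F)F)c3)c21`: 750 nM
Compound 2 `O=S1(=O)C=Cc2cccc(Nc3ccc(OC(F)(F)F)cc3)c21`: 2690 nM

Both values come from a functional assay on MCF7 cells (Homo sapiens) for antiproliferative activity, read by MTT assay, with a stated time of 72 h; on this read-out higher numbers stand for weaker inhibition and lower numbers for stronger inhibition. Compound 2, at 2690 nM, has the higher number of the two and so is the weaker inhibitor, and its gap to compound 1 lies beyond the usual scatter.

Compound 3 `O=S1(=O)C=Cc2cccc(Nc3ccc(C(F)(F)F)cc3)c21` is compound 2 with one change: trifluoromethyl in place of trifluoromethoxy on an aromatic carbon, para to a large group (trifluoromethyl in place of trifluoromethoxy on an aromatic carbon). Among the measured compounds shown here, no measured pair shows this swap on its own, so the evidence is thin. Compound 1 also carries trifluoromethyl and gives 750 nM, which suggests a small move toward stronger inhibition in this assay. The expected change is a 1.8-fold lower number from compound 2 to compound 3 (0.25 log units; within the scatter). For compound 3 the estimated value is 1500 nM, with an expected range from 500 nM to 4500 nM.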

Compound 3, half-maximal inhibitory concentration: 1820 nM
Beside the measured number, compound 3's estimate is 1.2-fold (0.08 log units) below it; the range from low to high includes it.
By their numbers in this assay, from the lowest: compound 1; then compounds 3 and 2 (each within the scatter of the next).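

Among the compounds shown here, this gives the first direct reading of the swap at this position: in this assay, trading trifluoromethoxy for trifluoromethyl gives a 1.5-fold lower number from compound 2 to compound 3 (0.17 log units; within the scatter). On an aromatic carbon para to a large group, then, removing the oxygen and the one hydrogen-bond acceptor counted for trifluoromethoxy produces no difference that this read-out can separate from the usual scatter. There is no measurement at hand that bears on why the two groups read so alike.

Still open, as far as these compounds go, is whether a different kind of group at this position, such as an amine, a carboxylic acid or a longer chain, would shift the number beyond the scatter. The compounds shown also leave open whether the swap would read the same with the group placed as it is in compound 1.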